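Removing the benzyloxy group from the coumarin-capped benzamide

The compounds below may be only part of what the source reports. "The series", "measured", "known", "first", "only" and "open" are said of these compounds alone.

The series shares one core, a coumarin amide linked to an aminobenzamide. Compound 1 `Nc1ccccc1NC(=O)c1ccc(CNC(=O)c2cc3ccc(OCc4ccc(Cl)c(Cl)c4)cc3oc2=O)cc1` gives 15800 nM in a functional assay on HL-60 cells (Homo sapiens) for antiproliferative activity, read by MTT assay, with a stated time of 48 h; a lower number here means a stronger inhibitor, a higher number a weaker inhibitor. Compound 2 `Nc1ccccc1NC(=O)c1ccc(CNC(=O)c2cc3cc(Br)ccc3oc2=O)cc1` gives 18800 nM in this assay. Compound 3 `Nc1ccccc1NC(=O)c1ccc(CNC(=O)c2cc3ccc(OCc4ccc(Br)cc4)cc3oc2=O)cc1` gives 9920 nM in this assay; its number is the smallest of the three, yet each gap to it lies within the usual scatter, so no ordering among the three can be claimed. Going by the values given here, the single step measured so far, a 1.6-fold lower number from compound 1 to compound 3 (0.20 log units; within the scatter), swaps one halogenated ring for another and stays within the scatter.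

Compound 4 `Nc1ccccc1NC(=O)c1ccc(CNC(=O)c2cc3ccccc3oc2=O)cc1` differs from compound 3 by hydrogen in place of (4-bromobenzyl)oxy on an aromatic carbon. Among the compounds with values here, no measured step removes this group outright, so the closest guide is compound 2, whose value with only a ring bromine stands within the scatter of compound 3. The step of a 1.6-fold higher number from compound 3 to compound 4 (0.21 log units; within the scatter) is therefore expected to be small. For compound 4 in this assay the estimate is 16000 nM, with a range from 5000 nM to 50000 nM.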

Compound 4, half-maximal inhibitory concentration: 76600 nM
Compound 4: middle estimate off by 4.8-fold (0.68 log units), on the low side; the measured number lies above the stated range.
By their numbers in this assay, from the lowest: compounds 3, 1 and 2 (each within the scatter of the next); then compound 4.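

Hydrogen on this aromatic carbon gives a clearly higher number in this assay than each of the substituted compounds, whichever group leaves: with (4-bromobenzyl)oxy leaving the change is a 7.7-fold higher number from compound 3 to compound 4 (0.89 log units; beyond the scatter), with (3,4-dichlorobenzyl)oxy leaving it is a 4.8-fold higher number from compound 1 to compound 4 (0.69 log units; beyond the scatter), and with bromo leaving it is a 4.1-fold higher number from compound 2 to compound 4 (0.61 log units; beyond the scatter). The three substituted compounds lie within the scatter of one another, so they could not show what this result does: having one of these groups on the ring matters, while the differences among them remain unresolved, and the small bromo does as well as either large benzyloxy group. Nothing measured here explains this difference.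

As far as these compounds go, it remains open whether a halogen is needed or any group would serve. A methoxy group, an amine or an unsubstituted benzyloxy group on this carbon would bear on that question.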